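From methylamino to methyl in the furan-3-yl series

The source may report more compounds than this note shows. Statements on the series, on what has been measured and on what is new or still open speak of the compounds shown alone.

Measured in a functional assay on K562 cells (Homo sapiens), read by MTT assay, with a stated time of 72 h; a higher number here means a weaker inhibitor, a lower number a stronger inhibitor:
Compound 1 `CSc1ncnc2c1c(-c1ccoc1)cn2[C@@H]1O[C@H](CO)[C@@H](O)[C@H]1O`: 60 nM
Compound 2 `CNc1ncnc2c1c(-c1ccoc1)cn2[C@@H]1O[C@H](CO)[C@@H](O)[C@H]1O`: > 20000 nM
Compound 3 `CNc1ncnc2c1c(-c1ccccc1)cn2[C@@H]1O[C@H](CO)[C@@H](O)[C@H]1O`: > 20000 nM

Compound 2 stands at the limit of > 20000 nM in this assay, at which 2 of the 3 values shown sit, and this is a limit, not a number. Compound 3 stands at the same limit. The swap of furan-3-yl for phenyl gives a step that the two limits leave unreadable from compound 2 to compound 3, so it offers no guide here.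

Compound 4 `Cc1ncnc2c1c(-c1ccoc1)cn2[C@@H]1O[C@H](CO)[C@@H](O)[C@H]1O` has not yet been measured. It differs by methyl in place of methylamino on an aromatic carbon. For the measured compounds named here, the one measured step at this place is an at least 330-fold higher number from compound 1 to compound 2 (2.52 log units; beyond the scatter), which is large. Read in reverse, it shows that a compound with furan-3-yl and without methylamino can give a real value, as compound 1 does at 60 nM. Methyl is not methylsulfanyl, however, so only part of that size is expected to return. In this assay the expected result is an at least 33-fold lower number from compound 2 to compound 4 (1.52 log units; beyond the scatter), towards a stronger inhibitor. Compound 4 is estimated at 600 nM, with an expected range from 60 nM to 10000 nM.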

Compound 4, half-maximal inhibitory concentration: > 20000 nM
Compound 4 was reported as a limit; the forecaster's own chance of this, stated with the estimate: 20%; at least 33-fold (1.52 log units) between middle value and limit.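

In this assay compound 4 gives > 20000 nM, a limit and not a number, so its step from compound 2 cannot be read. Methyl in place of methylsulfanyl gives an at least 330-fold higher number from compound 1 to compound 4 (2.52 log units; beyond the scatter), so the large loss seen at this position is not tied to methylamino alone. With furan-3-yl held fixed, methylsulfanyl is the only one of the three groups at this position to give a readable value, and the other two sit at the same limit: the limit of > 20000 nM in this assay, at which 3 of the 4 values shown sit.

Going by these compounds, it remains open whether another group at this position, such as ethylsulfanyl or methoxy, could keep a value near that of compound 1, 60 nM. On these data alone, it also remains open whether methylsulfanyl would keep its value with phenyl in place of furan-3-yl.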